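Phenyl in place of cyclohexyl on the shared core

The compounds below may be only part of what the source reports. "The series", "measured", "known", "first", "only" and "open" are said of these compounds alone.

In a functional assay on SW620/5-FU cells (Homo sapiens) for cytotoxicity, read by MTT assay, with a stated time of 48 h, in the presence of a further agent that is not named here (on this read-out lower numbers stand for an effect already at smaller amounts and higher numbers for an effect only at larger amounts of compound), compound 3 (`Cc1nn(C)c2nc(NNC(=O)Nc3cc(Cl)nc(Cl)c3)cc(C3CCCCC3)c12`) gives 22000 nM. This lies within the scatter of compound 2 (`Cn1nc(C(F)(F)F)c2c(-c3ccccc3)cc(NNC(=O)Nc3cc(Cl)nc(Cl)c3)nc21`), which gives 13100 nM. The value of compound 3 lies beyond the scatter of compound 1 (`COc1ccc(-c2cc(NNC(=O)Nc3cc(Cl)nc(Cl)c3)nc3c2c(C)nn3C)cc1`), which gives 9700 nM. The next comparison is compound 4 (`Cc1nn(C)c2nc(NNC(=O)Nc3cc(Cl)nc(Cl)c3)cc(-c3ccccc3)c12`), with phenyl in place of cyclohexyl on an aromatic carbon. For the measured compounds named here, the one measured step bearing on this change is modest: a 2.3-fold higher number from compound 1 to compound 3 (0.36 log units; beyond the scatter), with cyclohexyl in place of 4-methoxyphenyl. A step of similar modest size, toward a lower number, is therefore expected in this assay, namely a 2.0-fold lower number from compound 3 to compound 4 (0.30 log units; within the scatter). For compound 4 the estimated value is 11000 nM, with an expected range of 5500 nM to 21000 nM.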

Compound 4, half-maximal effective concentration: 22900 nM
Compound 4: middle estimate off by 2.1-fold (0.32 log units), on the low side; the whole stated range lies below it.
By their numbers in this assay, from the lowest: compounds 1, 2, 3 and 4 (each within the scatter of the next, the first and the last beyond it).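

In this assay, a 1.0-fold higher number from compound 3 to compound 4 (0.02 log units; within the scatter) shows that at this carbon, opposite the ring nitrogen, phenyl and cyclohexyl are not told apart, so the ring being aromatic carries no visible weight. For the compounds shown here, the only step here beyond the scatter is the loss of methoxy, a 2.4-fold higher number from compound 1 to compound 4 (0.37 log units; beyond the scatter), while the swap of trifluoromethyl for methyl stays within it, a 1.7-fold higher number from compound 2 to compound 4 (0.24 log units; within the scatter). The earlier gap between the 4-methoxyphenyl and cyclohexyl compounds therefore tracks the methoxy rather than the ring type. As far as these compounds go, whether an amine or a carboxylic acid in place of methoxy would shift the number remains open. No measurement at hand gives a reason for any of these steps.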